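Swapping 4-bromophenyl for 1-benzofuran-2-yl at the assay limit

The compounds below may be only part of what the source reports. "The series", "measured", "known", "first", "only" and "open" are said of these compounds alone.

Values in an ADME assay on HEK293 cells (Homo sapiens) for cytotoxicity (a lower number here means a stronger inhibitor, a higher number a weaker inhibitor), and each one a limit
Compound 1 `COC(=O)c1c(C)cc(OC(=O)c2c(C)cc(O)c(/C=N/NC(=O)COc3ccccc3C)c2O)c(C)c1O` gives > 100000 nM as a limit
Compound 2 `COC(=O)c1c(C)cc(OC(=O)c2c(C)cc(O)c(/C=N/NC(=O)COc3cccc(C)c3)c2O)c(C)c1O` gives > 100000 nM as a limit
Compound 3 `COC(=O)c1c(C)cc(OC(=O)c2c(C)cc(O)c(/C=N/NC(=O)COc3ccc(Br)cc3)c2O)c(C)c1O` gives > 100000 nM as a limit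

Compound 3 has only a limit and no number. The shared picture is the limit of > 100000 nM in this assay, at which 3 of the 3 values shown sit, and gives no ranking. Compound 4 `COC(=O)c1c(C)cc(OC(=O)c2c(C)cc(O)c(/C=N/NC(=O)COc3cc4ccccc4o3)c2O)c(C)c1O` brings the change 1-benzofuran-2-yl in place of 4-bromophenyl on an oxygen on a saturated carbon and so adds a five-membered aromatic ring with 1 hetero atom. The steps a step that the two limits leave unreadable from compound 1 to compound 3 and a step that the two limits leave unreadable from compound 2 to compound 3 bear on it, since both also exchange the group on that oxygen, yet neither has a readable size. The expected change is a number no higher from compound 3 to compound 4 (the limit leaves the size open) in this assay with no step beyond the scatter anticipated in either direction. For compound 4 the estimated value is 100000 nM with an expected range from 45000 nM to 150000 nM and it may well be only a limit.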

Compound 4, half-maximal inhibitory concentration: 84400 nM
Estimate against measurement, compound 4: 1.2-fold (0.07 log units) above, within the range that was stated.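

Compound 4, with 1-benzofuran-2-yl on the oxygen on a saturated carbon, is the only compound shown that gives a number rather than a limit in this assay while the steps among compound 1, compound 2 and compound 3 cannot be read. As far as these compounds go, the new steps are an at least 1.1-fold lower number from compound 3 to compound 4 (0.07 log units; that floor lies within the scatter) and an at least 1.1-fold lower number from compound 2 to compound 4 (0.07 log units; that floor lies within the scatter) and an at least 1.1-fold lower number from compound 1 to compound 4 (0.07 log units; that floor lies within the scatter) and each is only a floor, so their true sizes stay unknown. The series still rests mainly on one limit: the limit of > 100000 nM in this assay, at which 3 of the 4 values shown sit.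

From the compounds shown here alone, whether an amine or a carboxylic acid in place of 1-benzofuran-2-yl would shift the number beyond the scatter remains open.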